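Phenyl added to compound 1: expected antiproliferative read-out

The source may hold more compounds than are shown below. What is called first, only, known or untested is meant among the compounds shown, and "the series" means these compounds.

Compound 1 `Nc1ccccc1NC(=O)c1ccc(COCNc2nc(Nc3ccccc3)c3ncn(C4CCCC4)c3n2)cc1` serves as the reference for this step. In a functional assay on HCT-116 cells (Homo sapiens) for antiproliferative activity, read by CCK-8 assay, with a stated time of 72 h, tested at 8 uM (on this read-out lower numbers stand for a weaker effect and higher numbers for a stronger effect at the one concentration tested), compound 1 gives 76.9%; the only other measured compound, compound 2 `CCCCn1cnc2c(Nc3ccccc3)nc(NCOCc3ccc(C(=O)Nc4ccccc4N)cc3)nc21`, gives 74.9% in this assay, so on the numbers shown the two cannot be told apart. Within the data shown here, the one measured step, a number 2 percentage points lower from compound 1 to compound 2 (within the scatter), concerns butyl in place of cyclopentyl on an aromatic nitrogen and lies within the scatter. Compound 3 `Nc1ccccc1NC(=O)c1ccc(COCNc2nc(Nc3ccc(-c4ccccc4)cc3)c3ncn(C4CCCC4)c3n2)cc1` is not yet measured; it differs from compound 1 by phenyl in place of hydrogen on an aromatic carbon. Among the measured compounds shown here, that change is at a different place from the measured step, so no measured step bears on it directly; what the series shows so far is only that one substituent change left the read-out essentially where it was, and nothing is known about the effect of enlarging a group at this place. For compound 3 a step of a number 2.9 percentage points lower from compound 1 to compound 3 (within the scatter) is expected, meaning none beyond the scatter, with wider uncertainty than the measured pair gives. In this assay compound 3 is therefore estimated to give 74%, within a range from 50% to 90%.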

Compound 3, a percentage reported as inhibition, at one concentration (the size of the read-out at that concentration, not a potency): 25.8%
For compound 3 the middle estimate is 48.2 percentage points above the measured one, and the stated range ends above it.
By their numbers in this assay, from the lowest: compound 3; then compounds 2 and 1 (each within the scatter of the next).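

In this assay, among these compounds, the change of phenyl to 4-phenylphenyl comes with a number 51.1 percentage points lower from compound 1 to compound 3 (beyond the scatter) and is the first step to lie beyond the scatter. Among the compounds shown here, the read-out therefore depends on what sits at this aromatic carbon, para to a large group, whereas the only earlier change, butyl in place of cyclopentyl on an aromatic nitrogen, gave no step beyond the scatter. Nothing available bears on why the read-out falls with this change.

With a single entering group at this carbon, the compounds shown cannot say whether the loss belongs to an added aromatic ring as such or to any substituent there; a methyl, a methoxy, an amine or a fluorine at the same carbon would separate these readings. Also open, as far as these compounds go, is whether the butyl group on the aromatic nitrogen would leave the read-out of compound 3 as unaffected as it left that of compound 1, and whether the loss seen at the one tested concentration would carry over to a full concentration series.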